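Chloro for fluoro on the aryl ring of compound 3

The source may report more compounds than this note shows. Statements on the series, on what has been measured and on what is new or still open speak of the compounds shown alone.

Three compounds with a shared acidic side chain were examined in a functional assay on CHO cells for agonist activity at Free fatty acid receptor 1 (Homo sapiens), read by FLIPR and calcium flux; on this read-out higher numbers stand for an effect only at larger amounts of compound and lower numbers for an effect already at smaller amounts. Compound 1 `COc1cc(C)c(-c2cccc(COc3ccc4c(c3)C(O)CC4CC(=O)O)c2)c(C)c1` gives 550 nM, and compound 2 `COCCOc1cc(C)c(-c2cccc(COc3ccc(S(=O)(=O)CC(=O)O)cc3)c2)c(C)c1` gives 126 nM. Compound 3 `Cc1nc(-c2cccc(F)c2)sc1COc1ccc(S(=O)(=O)CC(=O)O)cc1`, which carries a thiazole-linked 3-fluorophenyl group in place of the biaryl of the other two, gives 275 nM in this assay . On these three numbers compound 3 stands second highest: its nearest neighbour is compound 1, whose number is higher by an amount that lies within the scatter of repeated measurements, while compound 2 is the furthest, with a lower number whose gap is beyond the scatter.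

Compound 4 `Cc1nc(-c2cccc(Cl)c2)sc1COc1ccc(S(=O)(=O)CC(=O)O)cc1` differs from compound 3 in one place only: chloro in place of fluoro on an aromatic carbon, on an aromatic carbon of a six-membered aromatic ring of carbon only, meta to a large group. Going by the values given here, no pair of measured compounds shows this exchange, so there is no direct step to lean on. Since the change is confined to a single halogen at the outer edge of the molecule, the step expected from compound 3 to compound 4 is small, a 1.4-fold lower number from compound 3 to compound 4 (0.14 log units; within the scatter), and may not rise beyond the scatter in this assay . Compound 4 is accordingly estimated at 200 nM, with a range from 80 nM to 600 nM.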

Compound 4, half-maximal effective concentration: 251 nM
Compound 4: middle estimate off by 1.3-fold (0.10 log units), on the low side; the range from low to high includes it.
By their numbers in this assay, from the lowest: compounds 2, 4, 3 and 1 (each within the scatter of the next, the first and the last beyond it).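

Going by these compounds alone, the exchange of 3-fluorophenyl for 3-chlorophenyl gives the first direct reading at this position: in this assay the step is a 1.1-fold lower number from compound 3 to compound 4 (0.04 log units; within the scatter), so on this pair the two halogens cannot be told apart. Until now, the compounds shown differed in more than one place, and none could say whether the number responds to a change on this six-membered aromatic ring of carbon only. Here one heavy atom replaces one heavy atom, with no hydrogen-bond donors or acceptors and no net charge on either side, and no separate measurement bears on why the two compounds read alike.

The compounds shown leave open whether the number would stay as it is with a group other than a halogen in this place, such as a methoxy group, a nitrile, a trifluoromethyl group or an amine, or with a plain phenyl group carrying hydrogen there. They also leave open whether the exchange of fluoro for chloro would read the same on the core of compound 1 or of compound 2.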